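Larger Group on the Aromatic Carbon: Expectation for Compound 4

A few compounds are considered here, and "the series" means these few. Any claim that something is new, unique, unknown or untested is made for them only; others in the source may bear on it.

Measured so far in a functional assay (Homo sapiens), tested at 10 uM; a higher number here means a weaker effect of the compound at the concentration tested, a lower number a stronger effect:
compound 1 `O=C(CCCc1ccc(C(F)(F)F)cn1)N1CCc2c(Cl)c(O)c(O)c(Cl)c2C1` gives 19%
compound 2 `O=C(CCCc1ncc(C(F)(F)F)cc1Cl)N1CCc2c(Cl)c(O)c(O)c(Cl)c2C1` gives 5%
compound 3 `Cc1cc(C(F)(F)F)cnc1CCCC(=O)N1CCc2c(Cl)c(O)c(O)c(Cl)c2C1` gives 7%

Compound 3 stands second highest of these three numbers, within the scatter of compound 2 and clearly apart from compound 1. Compound 4 `O=C(CCCc1ncc(C(F)(F)F)cc1C1CCCCC1)N1CCc2c(Cl)c(O)c(O)c(Cl)c2C1` differs from compound 3 in one place: cyclohexyl in place of methyl on an aromatic carbon. For the measured compounds named here, two measured steps bear on this position. Putting chloro in place of hydrogen gave a number 14 percentage points lower from compound 1 to compound 2 (beyond the scatter), and methyl in place of hydrogen gave a number 12 percentage points lower from compound 1 to compound 3 (beyond the scatter), while methyl in place of chloro gave a number 2 percentage points higher from compound 2 to compound 3 (within the scatter). Any group at this carbon so far lowered the number, and once lowered it stayed low. A bulkier group here is expected to behave similarly, so compound 4 is estimated at 6%, between 0% and 16%, a step of a number 1 percentage points lower from compound 3 to compound 4 (within the scatter) that is expected to lie within the scatter.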

Compound 4, a percentage reported as activity, at one concentration (the size of the read-out at that concentration, not a potency): 77%
Estimate against measurement, compound 4: 71 percentage points below; the measured number lies above the stated range.
By their numbers in this assay, from the lowest: compounds 2 and 3 (each within the scatter of the next); then compound 1; then compound 4.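

Hydrogen, chloro and methyl suggested that this aromatic carbon tolerates whatever is placed there, but cyclohexyl breaks that picture in this assay (a number 70 percentage points higher from compound 3 to compound 4 (beyond the scatter); a number 72 percentage points higher from compound 2 to compound 4 (beyond the scatter)). The number even ends well above the one with only hydrogen at this carbon (a number 58 percentage points higher from compound 1 to compound 4 (beyond the scatter)), so cyclohexyl does not merely lose the gain seen with chloro and methyl. Nothing available explains this reversal.

The compounds shown leave open where between methyl and cyclohexyl the number turns upward. Ethyl, isopropyl or phenyl at this carbon could keep it low or raise it.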